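Cytotoxicity notes: aniline in place of difluorophenyl

A few compounds are considered here, and "the series" means these few. Any claim that something is new, unique, unknown or untested is made for them only; others in the source may bear on it.

Measured compounds in an ADME assay on Huh-7 cells (Homo sapiens) for cytotoxicity; on this read-out lower numbers stand for higher toxicity in this test and higher numbers for lower toxicity in this test:
- Compound 1, `Cc1ccccc1-c1nn(-c2ccc(F)cc2F)cc1CNCCN1CCN(C)CC1`. In this assay compound 1 reaches only the limit > 20000 nM, so no number is known for it.
- Compound 2, `CCCN1CCC(CNCc2cn(-c3ccc(F)cc3F)nc2-c2ccccc2C)CC1`. In this assay compound 2 likewise sits at the limit > 20000 nM.
- Compound 3, `CN1CCN(CCNCc2cn(-c3ccc(F)cc3F)nc2-c2ccc(N(C)C)cc2)CC1`. In this assay compound 3 again gives the limit > 20000 nM.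

Compound 1 thus stands at a limit, not at a number, as do both of its measured neighbours: the limit of > 20000 nM in this assay, at which 3 of the 3 values shown sit.

The next compound, compound 4, `Cc1ccccc1-c1nn(-c2ccc(N)cc2)cc1CNCCN1CCN(C)CC1`, is not yet measured. It differs from compound 1 as follows: 4-aminophenyl in place of 2,4-difluorophenyl on an aromatic nitrogen.

Two measured steps start from compound 1. One is a step that the two limits leave unreadable from compound 1 to compound 2, the other is a step that the two limits leave unreadable from compound 1 to compound 3. For the measured compounds named here, neither is readable in size, since both ends sit at the limit; they show only that changes at the amine side chain and at the aromatic carbon of the core left the read-out at the limit. Neither step touches the aromatic nitrogen, so nothing measured bears directly on the change to compound 4. The expectation is therefore that compound 4 also stays near the limit, with the step that the limit leaves unreadable from compound 1 to compound 4 expected to lie within the scatter. Compound 4 is estimated at 25000 nM, with a range from 10000 nM to 60000 nM, and most likely reported as a limit again.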

Compound 4, half-maximal cytotoxic concentration: > 20000 nM
Compound 4 gave a limit, no number (the forecaster's own chance of this, stated with the estimate: 75%); the middle value does not contradict the limit.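

In this assay compound 4 gives > 20000 nM as a limit, not a number. Compound 1 also sits at a limit, so the step between them cannot be read. The compounds shown leave open what the actual values of compound 1 and compound 4 are, and whether 4-aminophenyl in place of 2,4-difluorophenyl changes the read-out at all.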